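The compounds below may be only part of what the source reports. "The series", "measured", "known", "first", "only" and "open" are said of these compounds alone.

Compound 1 `C=C(Br)C(=O)Nc1ccc(/C=C/C(=O)c2ccccc2)cc1` gives 3100 nM
Compound 2 `C=C(Br)C(=O)Nc1ccc(/C=C/C(=O)c2ccc(F)cc2)cc1` gives 660 nM
Compound 3 `Nc1ccc(/C=C/C(=O)c2ccccc2)cc1` gives 10000 nM

All three numbers come from a functional assay on MOLT-4 cells (Homo sapiens) for antiproliferative activity, with a stated time of 48 h (on this read-out higher numbers stand for weaker inhibition and lower numbers for stronger inhibition), and compound 3 at 10000 nM stands highest of them, making it the weakest inhibitor of the three. Compound 4 `Nc1ccc(/C=C/C(=O)c2ccc(F)cc2)cc1` has not yet been measured. It differs from compound 3 by one change, fluoro in place of hydrogen on an aromatic carbon is the full count. The same swap has been measured once, as a 4.7-fold lower number from compound 1 to compound 2 (0.67 log units; beyond the scatter) in a pair carrying the (1-bromoethenyl)carbonyl group on nitrogen. Compound 3 lacks that group, and a 3.2-fold higher number from compound 1 to compound 3 (0.51 log units; beyond the scatter) shows that the number moves with it, so the earlier step may not carry over in full. A lower number is still expected, with an estimated 3.3-fold lower number from compound 3 to compound 4 (0.52 log units; beyond the scatter) that is somewhat smaller. Compound 4 is estimated at 3000 nM with 1000 nM to 9000 nM as the expected range.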

Compound 4, half-maximal inhibitory concentration: 12000 nM
Beside the measured number, compound 4's estimate is 4.0-fold (0.60 log units) below it; measured number outside the range, above it.
By their numbers in this assay, from the lowest: compound 2; then compound 1; then compounds 3 and 4 (each within the scatter of the next).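

In this assay, fluoro on the aromatic carbon para to a large group brings no readable gain without the (1-bromoethenyl)carbonyl group on nitrogen: a 1.2-fold higher number from compound 3 to compound 4 (0.08 log units; within the scatter). What fluoro does here therefore depends on the group on that nitrogen: the same change on two cores in this assay, a 4.7-fold lower number (0.67 log units; beyond the scatter) from compound 1 to compound 2 and a 1.2-fold higher number (0.08 log units; within the scatter) from compound 3 to compound 4, 5.6-fold (0.75 log units) apart, beyond the scatter of two such steps. Likewise, losing that group costs more when fluoro is present, with an 18-fold higher number from compound 2 to compound 4 (1.26 log units; beyond the scatter), than when it is absent: the same change on two cores in this assay, a 3.2-fold higher number (0.51 log units; beyond the scatter) from compound 1 to compound 3 and an 18-fold higher number (1.26 log units; beyond the scatter) from compound 2 to compound 4, 5.6-fold (0.75 log units) apart, beyond the scatter of two such steps. From the compounds shown here alone, whether this link holds for another group on the nitrogen, such as acetyl, remains open. So does whether chloro or methoxy in fluoro's place would behave the same way.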